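Ester in place of primary amide on the shared core

This account rests on a few compounds, and the source may have more. Where it says the series, first, only, none or still open, it means among the compounds named here.

Measured so far:
compound 1 `COC(=O)c1ccc2c(ccn2-c2ccc(NC(=O)Nc3ccc(Cl)c(Cl)c3)cc2)n1` — 2800 nM
compound 2 `NC(=O)c1ccc2c(ccn2-c2ccc(NC(=O)c3cccc(C(F)(F)F)c3)cc2)n1` — > 10000 nM
compound 3 `NC(=O)c1ccc2c(ccn2-c2ccc(NC(=O)c3ccc(Cl)c(C(F)(F)F)c3)cc2)n1` — > 10000 nM

In an ADME assay on HS27 cells (Homo sapiens) for cytotoxicity, read by MTT assay (on this read-out lower numbers stand for stronger inhibition and higher numbers for weaker inhibition), compound 1 gives 2800 nM. Compound 2 reaches only a limit of the assay, > 10000 nM. Compound 3 likewise sits at a limit, > 10000 nM. Going by the values given here, the one measured step, a step that the two limits leave unreadable from compound 2 to compound 3, is therefore unreadable, and the limit of > 10000 nM in this assay, at which 2 of the 3 values shown sit, is where compound 2 stands: at the limit, with no number to anchor a step.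

Compound 4 `COC(=O)c1ccc2c(ccn2-c2ccc(NC(=O)c3cccc(C(F)(F)F)c3)cc2)n1` differs from compound 2 by methoxy in place of amino on a carbonyl carbon. Among the compounds with values here, no measured step covers this change. Compound 1 carries the methoxycarbonyl and gives a number rather than a limit, but its other part differs, so its value shows only that such an ester can read as a number.

For compound 4 a move toward stronger inhibition is estimated, an at least 1.2-fold lower number from compound 2 to compound 4 (0.09 log units; that floor lies within the scatter), giving an expected 8000 nM (range 2500 nM to 30000 nM).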

Compound 4, half-maximal inhibitory concentration: 9800 nM
Compound 4: the middle estimate sits 1.2-fold (0.09 log units) below what was measured; low and high end bracket the measured number.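

With methoxy in place of amino on a carbonyl carbon, this assay gives only a floor for this change: an at least 1.0-fold lower number from compound 2 to compound 4 (0.00 log units; that floor lies within the scatter). No shift beyond the scatter can be claimed at this position. Between the two esters, the other part of the molecule does matter, with 3-(trifluoromethyl)phenyl in place of (3,4-dichlorophenyl)amino on a carbonyl carbon giving a 3.5-fold higher number from compound 1 to compound 4 (0.54 log units; beyond the scatter).

On these data alone, the full size of the amide-to-ester step stays open because compound 2 is only a limit: the limit of > 10000 nM in this assay, at which 2 of the 4 values shown sit. How a carboxylic acid or an ethyl ester would read at this carbonyl carbon also stays open.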